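Nitro to cyano: cytotoxicity in HeLa cells

The compounds below may be only part of what the source reports. "The series", "measured", "known", "first", "only" and "open" are said of these compounds alone.

Compound 1 `O=c1ccoc2cc(OCc3cn(Cc4ccc(F)cc4)nn3)ccc12` gives 12000 nM in a functional assay on HeLa cells (Homo sapiens) for cytotoxicity, read by MTT assay, with a stated time of 48 h; a higher number here means a weaker inhibitor, a lower number a stronger inhibitor.
Compound 2 `O=c1ccoc2cc(OCc3cn(Cc4ccc(Br)cc4)nn3)ccc12` reaches only the limit of > 100000 nM in this assay.
Compound 3 `O=c1ccoc2cc(OCc3cn(Cc4ccc([N+](=O)[O-])cc4)nn3)ccc12` gives 25700 nM in this assay.

Among the two numbers, compound 3 holds the higher one; compound 1 stands nearest, with the step of a 2.1-fold higher number from compound 1 to compound 3 (0.33 log units; beyond the scatter). Compound 2 sits at a limit (the limit of > 100000 nM in this assay, at which 1 of the 3 values shown sits), and the step of an at least 3.8-fold lower number from compound 2 to compound 3 (0.59 log units; beyond the scatter) is also beyond the scatter. Compound 4 `N#Cc1ccc(Cn2cc(COc3ccc4c(=O)ccoc4c3)nn2)cc1` differs from compound 3 by cyano in place of nitro on an aromatic carbon. Among the measured compounds shown here, no measured step involves cyano, so the two steps touching compound 3 only show that changes at this position move the number modestly in either direction. Compound 4 is therefore expected near compound 3, at 20000 nM, within 8000 nM to 60000 nM. This means an expected step of a 1.3-fold lower number from compound 3 to compound 4 (0.11 log units; within the scatter), not beyond the scatter.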

Compound 4, half-maximal inhibitory concentration: > 100000 nM
Compound 4: only a limit was reported; the forecaster's own chance of this, stated with the estimate: 10%; middle value at least 5.0-fold (0.69 log units) from the limit.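

Nitro to cyano on this aromatic carbon is enough to lose a readable number in this assay: there is an at least 3.8-fold higher number from compound 3 to compound 4 (0.59 log units; beyond the scatter), and also an at least 8.3-fold higher number from compound 1 to compound 4 (0.92 log units; beyond the scatter). Among the four para-substituted compounds, only the fluoro and nitro groups therefore give a readable number. Compound 4 reaches only a limit, as compound 2 does, so the step between these two cannot be read: the limit of > 100000 nM in this assay, at which 2 of the 4 values shown sit.

From the compounds shown here alone, it remains open whether an amine or a carboxylic acid at this place would give a readable number. Going by these compounds, how compound 2 and compound 4 compare beyond their shared limit also stays unknown.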